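The source may hold more compounds than are shown below. What is called first, only, known or untested is meant among the compounds shown, and "the series" means these compounds.

Going by the values given here, in an ADME assay on L6 cells (Rattus norvegicus) for cytotoxicity (a higher number here means a weaker inhibitor, a lower number a stronger inhibitor), compound 1 `O=C(Nc1c(O)cccc1-c1nc2c(C(=O)O)cccc2o1)c1ccccn1`, which carries a pyridin-2-yl group on a carbonyl carbon, gives 30600 nM, the lowest number of the three measured so far. Compound 2 `O=C(Nc1c(O)cccc1-c1nc2c(C(=O)O)cccc2o1)c1ncccc1F` gives 204000 nM and compound 3 `O=C(Nc1c(O)cccc1-c1nc2c(C(=O)O)cccc2o1)c1cccc(Cl)c1` gives 143000 nM. These last two cannot be told apart, as a 1.4-fold lower number from compound 2 to compound 3 (0.15 log units; within the scatter) shows.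

Compound 4 `O=C(Nc1c(O)cccc1-c1nc2c(C(=O)O)cccc2o1)c1cccnc1` has not yet been measured. It has the same atoms as compound 1, joined differently, and the change is confined to one ring: pyridin-3-yl in place of pyridin-2-yl on a carbonyl carbon.

Among the compounds with values here, no measured step makes this exact swap, so the evidence is indirect. Two steps alter the same ring, and both are modest and upward. The first is a 6.7-fold higher number from compound 1 to compound 2 (0.82 log units; beyond the scatter), with fluoro in place of hydrogen on an aromatic carbon. The second is a 4.7-fold higher number from compound 1 to compound 3 (0.67 log units; beyond the scatter), with 3-chlorophenyl in place of pyridin-2-yl. Neither step shows how a pyridin-3-yl group behaves, but the new group is the same size as the old one, so a smaller rise seems a reasonable expectation, and no real change remains possible.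

The step expected on this reasoning is a 2.5-fold higher number from compound 1 to compound 4 (0.39 log units; beyond the scatter). For compound 4 the estimated value is 75000 nM, with an expected range from 28000 nM to 190000 nM.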

Compound 4, half-maximal inhibitory concentration: 240000 nM
The estimate for compound 4 lay 3.2-fold (0.51 log units) below the measured number, and the stated range ends below it.
By their numbers in this assay, from the lowest: compound 1; then compounds 3, 2 and 4 (each within the scatter of the next).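

In this assay, replacing pyridin-2-yl with pyridin-3-yl on the carbonyl carbon gives a 7.8-fold higher number from compound 1 to compound 4 (0.89 log units; beyond the scatter) even though no atom is added or removed, so at this position the way the ring is attached matters as much as what it carries. Compound 4 cannot be told apart from the two substituted analogues, with a 1.7-fold higher number from compound 3 to compound 4 (0.22 log units; within the scatter) and a 1.2-fold higher number from compound 2 to compound 4 (0.07 log units; within the scatter) both printed as within the scatter. Among these four compounds, only compound 1 stands apart, and a pyridin-2-yl ring alone does not guarantee its low number, since compound 2 goes against that pattern by carrying a fluoro on the same ring. Nothing measured here explains why this change has such an effect.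

As far as these compounds go, it remains open whether the low number is specific to pyridin-2-yl, which a pyridin-4-yl or a plain phenyl group on the same carbonyl carbon would help to settle. From the compounds shown here alone, it is also open whether a methyl or an amino group on the pyridin-2-yl ring would behave as the fluoro does in compound 2.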